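The compounds below may be only part of what the source reports. "The series", "measured", "known", "first", "only" and "open" are said of these compounds alone.

Three compounds share the core shown in compound 1 `O=C(/C=C/c1ccc2c(c1)B(O)OC2)c1ccccc1` and differ only in the group carried on the six-membered aromatic ring of carbon only. In a toxicity assay on WI-38 cells (Homo sapiens) for cytotoxicity, read by MTT assay, with a stated time of 48 h (on this read-out lower numbers stand for stronger inhibition and higher numbers for weaker inhibition), compound 1 gives 19100 nM. Compound 3 `O=C(/C=C/c1ccc2c(c1)B(O)OC2)c1ccc(C(F)(F)F)cc1` gives 22600 nM, and the step of a 1.2-fold higher number from compound 1 to compound 3 (0.07 log units; within the scatter) is small. Compound 2 `O=C(/C=C/c1ccc2c(c1)B(O)OC2)c1ccc(I)cc1` gives only a limit, > 100000 nM. The steps of an at least 5.2-fold higher number from compound 1 to compound 2 (0.71 log units; beyond the scatter) and an at least 4.4-fold lower number from compound 2 to compound 3 (0.64 log units; beyond the scatter) are larger, both resting on (the limit of > 100000 nM in this assay, at which 1 of the 3 values shown sits). Compound 3 and compound 1 sit within the scatter of each other, so neither stands apart. Compound 4 `O=C(O)c1ccc(C(=O)/C=C/c2ccc3c(c2)B(O)OC3)cc1` carries carboxy in place of trifluoromethyl on an aromatic carbon. Among the compounds with values here, the one comparable swap on this ring, a 1.2-fold higher number from compound 1 to compound 3 (0.07 log units; within the scatter), stayed within the scatter, and a step of a 1.1-fold higher number from compound 3 to compound 4 (0.04 log units; within the scatter) of similar size is expected. Compound 4 is therefore estimated at 25000 nM, between 8000 nM and 80000 nM.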

Compound 4, half-maximal inhibitory concentration: > 100000 nM
Compound 4 ended at the assay's limit; the forecaster's own chance of this, stated with the estimate: 15%; middle value at least 4.0-fold (0.60 log units) from the limit.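

Within the data shown here, replacing trifluoromethyl with carboxy gives an at least 4.4-fold higher number from compound 3 to compound 4 (0.64 log units; beyond the scatter) in this assay and replacing hydrogen with carboxy gives an at least 5.2-fold higher number from compound 1 to compound 4 (0.71 log units; beyond the scatter) so iodo is no longer the only group on this ring that moves the number beyond the scatter. Compound 3, with trifluoromethyl, goes against any simple rule that a group here pushes the number up. Both steps rest on a limit: the limit of > 100000 nM in this assay, at which 2 of the 4 values shown sit. The step between compound 2 and compound 4 cannot be read. From the compounds shown here alone, whether an amine or a methoxy group here would stay near compound 1 remains open, as does what iodo and carboxy share.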